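This account rests on a few compounds, and the source may have more. Where it says the series, first, only, none or still open, it means among the compounds named here.

Compound 3, `COc1ccc(C(=O)/C=C/c2cc(-c3cc(OC)c(OC)c(OC)c3)n[nH]2)cc1`, gives 3060 nM in a functional assay on KM12 cells (Homo sapiens) for inhibition, read by sulforhodamine B assay, with a stated time of 48 h (a lower number here means a stronger inhibitor of growth, a higher number a weaker inhibitor of growth), the highest of the two numbers in hand, though compound 1, `COc1cc(-c2cc(/C=C/C(=O)c3ccc(N)cc3)[nH]n2)cc(OC)c1OC`, with 2880 nM, is its nearest neighbour and the two are within the scatter (a 1.1-fold higher number from compound 1 to compound 3 (0.03 log units; within the scatter)). Compound 2, `COc1cc(-c2cc(/C=C/C(=O)c3ccc(Cl)c(Cl)c3)[nH]n2)cc(OC)c1OC`, gives > 100000 nM, which is a limit of the assay and not a number. Within the data shown here, two measured steps bear on the change ahead: the exchange of 4-aminophenyl for 3,4-dichlorophenyl on the carbonyl carbon gave an at least 34-fold higher number from compound 1 to compound 2 (1.54 log units; beyond the scatter), and the reverse exchange back to 4-methoxyphenyl gave an at least 32-fold lower number from compound 2 to compound 3 (1.51 log units; beyond the scatter). Compound 4, `COc1cc(-c2cc(/C=C/C(=O)c3ccc(F)c(F)c3)[nH]n2)cc(OC)c1OC`, differs from compound 3 in one place: 3,4-difluorophenyl in place of 4-methoxyphenyl on a carbonyl carbon. Since the only dihalogenated phenyl measured, compound 2, sits at the limit (the limit of > 100000 nM in this assay, at which 1 of the 3 values shown sits), a large step upward in this assay is expected for compound 4, though its size is uncertain. Compound 4 is therefore estimated at 25000 nM, between 6000 nM and 100000 nM, a step of an 8.2-fold higher number from compound 3 to compound 4 (0.91 log units; beyond the scatter) expected from compound 3.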

Compound 4, concentration for total growth inhibition: 11400 nM
Beside the measured number, compound 4's estimate is 2.2-fold (0.34 log units) above it; low and high end bracket the measured number.
By their numbers in this assay, from the lowest: compounds 1 and 3 (each within the scatter of the next); then compound 4. At a limit, above all of these: compound 2.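

The 3,4-difluorophenyl group shows that a dihalogenated phenyl on the carbonyl carbon can still give a readable number in this assay, with an at least 8.7-fold lower number from compound 2 to compound 4 (0.94 log units; beyond the scatter). Compound 2 remains a limit and not a number: the limit of > 100000 nM in this assay, at which 1 of the 4 values shown sits.

Even so, the exchange does not match the two groups with a single substituent, with a 3.7-fold higher number from compound 3 to compound 4 (0.57 log units; beyond the scatter) and a 4.0-fold higher number from compound 1 to compound 4 (0.60 log units; beyond the scatter), so 4-methoxyphenyl and 4-aminophenyl both give lower numbers than 3,4-difluorophenyl here. The compounds shown leave open whether both fluorines matter, which a phenyl carrying one fluorine or a plain phenyl on the carbonyl carbon would settle. They also leave open whether the lower numbers of compound 1 and compound 3 extend to other groups on that phenyl, such as a hydroxyl or a dimethylamino group.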